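Lactone series: removing an aryl group toward a diol

This account rests on a few compounds, and the source may have more. Where it says the series, first, only, none or still open, it means among the compounds named here.

Compound 1 `O=C1C[C@H]2O[C@H](Cc3ccccc3)[C@H](OCc3ccccc3)[C@H]2O1` gives 140 nM in a functional assay on K562 cells (Homo sapiens) for antiproliferative activity, read by MTT assay, with a stated time of 72 h; a higher number here means a weaker inhibitor, a lower number a stronger inhibitor. For the measured compounds named here, compound 2 `Cc1ccccc1[C@H](c1ccccc1)[C@H]1O[C@@H]2CC(=O)O[C@@H]2[C@H]1O` gives 1560 nM in this assay, the highest of the three numbers so far; compound 3 `O=C1C[C@H]2O[C@@H]3[C@@H](c4ccccc4)c4ccccc4CO[C@@H]3[C@H]2O1` gives 1430 nM, which lies within the scatter of compound 2, while compound 1 sits well beyond the scatter at the stronger end. Compound 4 `O=C1C[C@H]2O[C@H]([C@H](O)c3ccccc3)[C@H](O)[C@H]2O1` has not been measured. Its difference from compound 2: hydroxy in place of 2-methylphenyl on a saturated chain carbon bound to an aromatic carbon and a saturated ring carbon. Going by the values given here, no measured pair shows such a change here. A modest step in the weaker direction is expected, since all three measured compounds carry at least two aromatic rings and compound 4 keeps one. For compound 4 the estimate in this assay is 3500 nM, range 900 nM to 15000 nM. The expected step of a 2.2-fold higher number from compound 2 to compound 4 (0.35 log units; beyond the scatter) is small against the scatter.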

Compound 4, half-maximal inhibitory concentration: 410 nM
Estimate against measurement, compound 4: 8.5-fold (0.93 log units) above; the measured number lies below the stated range.
By their numbers in this assay, from the lowest: compound 1; then compound 4; then compounds 3 and 2 (each within the scatter of the next).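

In this assay, on a saturated chain carbon bound to an aromatic carbon and a saturated ring carbon, hydroxy in place of 2-methylphenyl gives a 3.8-fold lower number from compound 2 to compound 4 (0.58 log units; beyond the scatter), a step toward the stronger end. At this position, then, the 2-methylphenyl ring is not required for activity, and this pair gains from its loss. Nothing at hand bears on the reason for this step.

Open, going by these compounds, is whether an amine or a methoxy group on this carbon would give a lower or higher number than hydroxy. Also open, on these data alone, is what replacing the phenyl ring still on this carbon would do.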